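Aryl swap on the ring nitrogen: what compound 4 may show

The source may hold more compounds than are shown below. What is called first, only, known or untested is meant among the compounds shown, and "the series" means these compounds.

Three measured compounds share one core and differ only in the aromatic group on the amine nitrogen in the ring. In a functional assay on CHO cells with adenosine receptor A1 (Homo sapiens) as the target, read by cAMP accumulation and immunoassay, with a stated time of 6 min, tested at 0.1 uM (on this read-out lower numbers stand for a stronger effect and higher numbers for a weaker effect at the one concentration tested), compound 1 `COc1ccc(N2CCN(Cc3csc(N)c3C(=O)c3ccc(Cl)cc3)CC2)cc1` gives 0%, compound 2 `Nc1scc(CN2CCN(c3ccc(OC(F)(F)F)cc3)CC2)c1C(=O)c1ccc(Cl)cc1` gives -13%, and compound 3 `Nc1scc(CN2CCN(c3cccnc3)CC2)c1C(=O)c1ccc(Cl)cc1` gives 3.4%. Compound 3 holds the highest of the three numbers; its gap to compound 1 lies within the scatter, while its gap to compound 2 is beyond it. Compound 4 `Nc1scc(CN2CCN(c3ccc(F)c(F)c3)CC2)c1C(=O)c1ccc(Cl)cc1` has not yet been measured. It differs from compound 3 by 3,4-difluorophenyl in place of pyridin-3-yl on an amine nitrogen in a ring. Going by the values given here, two measured steps bear on this change. Both exchange the aromatic group at the same place: a number 3.4 percentage points higher from compound 1 to compound 3 (within the scatter) and a number 16.4 percentage points higher from compound 2 to compound 3 (beyond the scatter). Each put pyridin-3-yl in place of a substituted phenyl and either left the number flat or moved it up. Compound 4 goes the other way, putting a substituted phenyl back in place of pyridin-3-yl, so a small downward step is expected, a number 6.4 percentage points lower from compound 3 to compound 4 (within the scatter), which may well stay within the scatter. Compound 4 is estimated in this assay at -3%, with a range from -15% to 9%.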

Compound 4, a percentage reported as activity, at one concentration (the size of the read-out at that concentration, not a potency): -34%
Beside the measured number, compound 4's estimate is 31 percentage points above it; measured number below the stated range.
By their numbers in this assay, from the lowest: compound 4; then compound 2; then compounds 1 and 3 (each within the scatter of the next).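

In this assay, going by these compounds alone, the aromatic group on the amine nitrogen in the ring can move the number much further than the earlier compounds showed: the new exchange gives a number 37.4 percentage points lower from compound 3 to compound 4 (beyond the scatter), whereas the widest earlier gap was a number 16.4 percentage points higher from compound 2 to compound 3 (beyond the scatter). A phenyl ring in place of pyridin-3-yl does not settle the outcome by itself, since two exchanges between substituted phenyl groups also matter, with a number 34 percentage points lower from compound 1 to compound 4 (beyond the scatter) and a number 21 percentage points lower from compound 2 to compound 4 (beyond the scatter), while compound 1 and compound 3 remain within the scatter of each other despite their different rings. Compound 4 therefore holds the lowest number of the four, beyond the scatter from each of the others, which on this read-out marks the strongest effect at the one concentration tested, though nothing available here explains that result.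

The compounds shown leave open whether both fluorines are needed, or whether a phenyl group with a single fluorine, or a chlorophenyl group, would give a similar number. A single concentration also leaves open how the compounds compare in potency.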